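Pleural inhibition series: thioether to fluoro on the ring carbon

A few compounds are considered here, and "the series" means these few. Any claim that something is new, unique, unknown or untested is made for them only; others in the source may bear on it.

Measured compounds:
compound 1 `CSC1(C)C(=O)N(c2ccccc2)c2ncccc21` — 34%
compound 2 `CCC1(C)C(=O)N(c2ccccc2)c2ncccc21` — 36%
compound 3 `COCCSC1(C)C(=O)N(c2ccccc2)c2ncccc21` — 26%

All three share one core and differ only at a saturated ring carbon. In a functional assay on the whole organism (Pleural cavity) for inhibition, with Rattus norvegicus as the target, at a dose of 25 mg/kg (a lower number here means less inhibition, a higher number more inhibition at the dose given (going by the name of the read-out)), compound 1 gives 34% and compound 2 gives 36%; compound 3 gives 26%. The steps of a number 8 percentage points lower from compound 1 to compound 3 (within the scatter) and a number 10 percentage points lower from compound 2 to compound 3 (within the scatter) place compound 3 within the scatter of both others, and a number 2 percentage points higher from compound 1 to compound 2 (within the scatter) shows the same for the two larger substituents.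

Compound 4 `CC1(F)C(=O)N(c2ccccc2)c2ncccc21` carries the change (fluoro in place of (2-methoxyethyl)sulfanyl on a saturated ring carbon). Within the data shown here, no measured step involves fluoro, but every substituent change at this carbon so far has stayed within the scatter, so no step beyond the scatter is expected in this assay, with the expected step being a number 4 percentage points higher from compound 3 to compound 4 (within the scatter). Compound 4 is therefore estimated at 30%, with a range of 15% to 45%.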

Compound 4, a percentage reported as inhibition, in the whole organism at one dose (the size of the read-out at that dose, not a potency): 50%
For compound 4 the middle estimate is 20 percentage points below the measured one; the whole stated range lies below it.
By their numbers in this assay, from the lowest: compounds 3, 1 and 2 (each within the scatter of the next); then compound 4.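

In this assay fluoro on this saturated ring carbon gives a number 24 percentage points higher from compound 3 to compound 4 (beyond the scatter) and a number 14 percentage points higher from compound 2 to compound 4 (beyond the scatter) as well as a number 16 percentage points higher from compound 1 to compound 4 (beyond the scatter) so the position does respond to its substituent. Fluoro, with its single heavy atom, stands apart from methylsulfanyl, ethyl and (2-methoxyethyl)sulfanyl, which remain within the scatter of one another. No evidence on the cause of this rise is available.

From the compounds shown here alone, whether the rise is specific to fluoro remains open, since hydroxyl, chloro or hydrogen at this carbon would test that. Going by these compounds, whether it would persist at other doses also remains open.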